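This account rests on a few compounds, and the source may have more. Where it says the series, first, only, none or still open, it means among the compounds named here.

Measured in a functional assay on HT-29 cells (Homo sapiens) for inhibition, read by MTT assay, with a stated time of 48 h; on this read-out lower numbers stand for stronger inhibition and higher numbers for weaker inhibition:
compound 1, `O=C(NC(=S)Nc1ccc(Cl)c(-c2nc3ccccc3[nH]2)c1)c1ccc(OCc2ccc(Cl)c(Cl)c2)cc1`, 4930 nM
compound 2, `O=C(NC(=S)Nc1ccc(Cl)c(-c2nc3ccccc3[nH]2)c1)c1ccc(OCc2ccc(Cl)cc2Cl)cc1`, 6080 nM
compound 3, `Cc1ccc(NC(=O)NC(=O)c2ccc(OCc3ccc(Cl)c(Cl)c3)cc2)cc1-c1nc2ccccc2[nH]1`, 1030 nM

Compound 1 and compound 2 share one core and differ only by 2,4-dichlorophenyl in place of 3,4-dichlorophenyl on a saturated chain carbon bound to an oxygen on an aromatic ring; that change made a 1.2-fold higher number from compound 1 to compound 2 (0.09 log units; within the scatter). Compound 3 has a different core, and how it differs from compound 1 is not broken down here. Compound 4, `Cc1ccc(NC(=O)NC(=O)c2ccc(OCc3ccc(Cl)cc3Cl)cc2)cc1-c1nc2ccccc2[nH]1`, is not yet measured; it stands to compound 3 as compound 2 stands to compound 1, differing by 2,4-dichlorophenyl in place of 3,4-dichlorophenyl on a saturated chain carbon bound to an oxygen on an aromatic ring, at a place described in the same words, so this is the same change. The step from compound 3 to compound 4 is expected to be a 1.2-fold higher number from compound 3 to compound 4 (0.08 log units; within the scatter), a small move like the one seen, because compound 1 and compound 2 showed a 1.2-fold higher number from compound 1 to compound 2 (0.09 log units; within the scatter). Compound 4 is therefore estimated at 1250 nM, most likely between 600 nM and 2600 nM.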

Compound 4, half-maximal inhibitory concentration: 2620 nM
Compound 4: the middle estimate sits 2.1-fold (0.32 log units) below what was measured, outside the stated range (above it).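

In this assay, putting 2,4-dichlorophenyl in place of 3,4-dichlorophenyl gave a 2.5-fold higher number from compound 3 to compound 4 (0.41 log units; beyond the scatter). Set beside the same change on the core of compound 1, this step cannot be told apart from the earlier one: the same change on two cores in this assay, a 1.2-fold higher number (0.09 log units; within the scatter) from compound 1 to compound 2 and a 2.5-fold higher number (0.41 log units; beyond the scatter) from compound 3 to compound 4, 2.1-fold (0.31 log units) apart, within the scatter of two such steps. The two pairs therefore give no sign that the core alters the effect of this change, but two pairs cannot show that it would carry over to every core in the series, nor fix its exact size.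

Going by these compounds, only dichlorophenyl groups appear at this place, so it remains open how a plain phenyl or a methoxyphenyl group would behave there. On these data alone, it also remains open whether either would respond to the core in the same way.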